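This account rests on a few compounds, and the source may have more. Where it says the series, first, only, none or still open, it means among the compounds named here.

Measured in a functional assay on a cell-free system (Platelet, plasma, Oryctolagus cuniculus) for inhibition, with a stated time of 5 min, at 37 degrees C; on this read-out lower numbers stand for stronger inhibition and higher numbers for weaker inhibition:

compound 1 `CCOC(=O)/C=C/c1ccc(OC(=O)c2nc(C)c(C)nc2C)c(O)c1` gives 77400 nM
compound 2 `Cc1nc(C)c(C(=O)Oc2ccc(/C=C/C(=O)O)cc2)nc1C` gives 37800 nM
compound 3 `CCOC(=O)/C=C/c1ccc(OC(=O)c2nc(C)c(C)nc2C)c(OC)c1` gives 58400 nM

Compound 3 sits among these three numbers, within the usual scatter of both compound 1 and compound 2. The next compound to be tested in this assay is compound 4 `CCOC(=O)/C=C/c1ccc(OC(=O)c2nc(C)c(C)nc2C)cc1` and it differs from compound 3 by one change: hydrogen in place of methoxy on an aromatic carbon. Hydrogen takes the place of methoxy on an aromatic carbon, and the rest of the molecule stays the same.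

Among the measured compounds shown here, only one measured step touches that carbon. It is a 1.3-fold lower number from compound 1 to compound 3 (0.12 log units; within the scatter) and it lies within the scatter, so changing the group on that oxygen moved the number very little. For the measured compounds named here, no measured step removes the oxygen itself, so this evidence is indirect. Compound 2 also has hydrogen on that carbon but carries a free carboxylic acid in place of the ethyl ester, which makes its 37800 nM only a loose guide.

No shift beyond the scatter is therefore expected in this assay, and no direction can be firmly assigned. The expected step is a 1.2-fold lower number from compound 3 to compound 4 (0.07 log units; within the scatter) in size. Compound 4 is estimated at 50000 nM with an expected range from 20000 nM to 120000 nM in this measurement.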

Compound 4, half-maximal inhibitory concentration: 24400 nM
Estimate against measurement, compound 4: 2.0-fold (0.31 log units) above, and the stated range covers the measured number.
By their numbers in this assay, from the lowest: compounds 4, 2, 3 and 1 (each within the scatter of the next, the first and the last beyond it).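

In (this assay), taking the oxygen group off this aromatic carbon, ortho to a large group, moves the number beyond the scatter, whether methoxy leaves (a 2.4-fold lower number from compound 3 to compound 4 (0.38 log units; beyond the scatter)) or hydroxy leaves (a 3.2-fold lower number from compound 1 to compound 4 (0.50 log units; beyond the scatter)), whereas the earlier change on the oxygen itself stayed within it (a 1.3-fold lower number from compound 1 to compound 3 (0.12 log units; within the scatter)). Among compounds 1, 3 and 4, hydrogen on that carbon therefore goes with the lower number, and the presence of the oxygen counts for more than what sits on it, while the ethyl ester and the free carboxylic acid, both with hydrogen on that carbon, remain within the scatter of each other (a 1.5-fold lower number from compound 2 to compound 4 (0.19 log units; within the scatter)). Nothing available here accounts for the shift.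

The compounds shown leave open whether other groups on that carbon, such as fluorine, chlorine, an amine or a longer ethoxy chain, would fall with hydrogen or with methoxy and hydroxy. They also leave open whether a free carboxylic acid in place of the ethyl ester would show the same shift when methoxy or hydroxy occupies that carbon.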